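This account rests on a few compounds, and the source may have more. Where it says the series, first, only, none or still open, it means among the compounds named here.

Working notes on the series. Two compounds carry numbers in a functional assay on HepG2 cells (Homo sapiens) for inhibition, read by sulforhodamine B assay, with a stated time of 72 h; a lower number here means a stronger inhibitor, a higher number a weaker inhibitor. Compound 1 `CC(C)[C@H](Nc1ncnc2[nH]cnc12)c1nn(-c2cccnc2)c2cc(F)ccc12` reaches only a limit of the assay in this assay, > 40000 nM, and the limit of > 40000 nM in this assay, at which 1 of the 2 values shown sits, marks the point at which that value sits. Among the measured compounds shown here, compound 2 `C[C@H](Nc1ncnc2[nH]cnc12)c1nn(-c2ccccn2)c2cc(F)ccc12` is the one compound with a measured number here: in this assay compound 2 gives 29900 nM, a weak inhibitor. For the measured compounds named here, no step between two measured compounds is available, since compound 1 and compound 2 differ in more than one place.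

Compound 3 `C[C@H](Nc1ncnc2[nH]cnc12)c1nn(-c2ccc(C#N)cc2)c2cc(F)ccc12` is not yet measured. The change from compound 2 is 4-cyanophenyl in place of pyridin-2-yl on an aromatic nitrogen. Going by the values given here, with no measured step to lean on, the expectation is that the step from compound 2 to compound 3 stays within the usual scatter, in either direction, with no change beyond it; that expectation is a 1.2-fold lower number from compound 2 to compound 3 (0.08 log units; within the scatter). On that basis compound 3 is estimated at 25000 nM in this assay, with a range from 8000 nM to 80000 nM.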

Compound 3, half-maximal inhibitory concentration: 15100 nM
For compound 3 the middle estimate is 1.7-fold (0.22 log units) above the measured one, and the stated range covers the measured number.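

Among the compounds shown here, this gives the first step that can be read at this position, on an aromatic nitrogen of the five-membered ring: in this assay the replacement of pyridin-2-yl by 4-cyanophenyl gives a 2.0-fold lower number from compound 2 to compound 3 (0.30 log units; within the scatter). The position therefore accepts a carbon-only aromatic ring bearing a nitrile in place of a ring with one hetero atom, with no change beyond the scatter, though loss of the ring nitrogen and gain of the nitrile cannot be separated in this one step. No measured property bears on this step.

Open, as far as these compounds go, is whether any group at this position gives a step beyond the scatter, for example a carboxylic acid or an amine on the aromatic ring, or a morpholine or a short alkyl chain in place of that ring. Also open, from the compounds shown here alone, is what the group on the carbon bearing the amine contributes, since compound 1 differs from compound 2 and compound 3 in more than one place.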